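This account rests on a few compounds, and the source may have more. Where it says the series, first, only, none or still open, it means among the compounds named here.

Within the data shown here, compound 1 `Cc1cccc(NC(=O)c2ccc(/N=N\c3c[nH]c4ccccc34)cc2)c1C` gives 272000 nM in a functional assay on HCT-116 cells (Homo sapiens) for inhibition, read by MTT assay, with a stated time of 72 h (a lower number here means a stronger inhibitor, a higher number a weaker inhibitor), the lowest of the two numbers so far; its nearest neighbour, compound 2 `O=C(Nc1ccccc1F)c1ccc(/N=N\c2c[nH]c3ccccc23)cc1`, gives 559000 nM in this assay, a 2.1-fold higher number from compound 1 to compound 2 (0.31 log units; beyond the scatter). Compound 3 `Cc1cccc(NC(=O)c2ccc(/N=N\c3c[nH]c4ccccc34)cc2)c1` differs from compound 1 by hydrogen in place of methyl on an aromatic carbon. Among the measured compounds shown here, no measured step isolates this change: the only step, a 2.1-fold higher number from compound 1 to compound 2 (0.31 log units; beyond the scatter), swaps the whole 2,3-dimethylphenyl for 2-fluorophenyl and is modest. Trimming a single methyl is a smaller alteration, so a step no larger than that is expected, most likely a slightly higher number. Compound 3 is therefore estimated at 350000 nM, between 150000 nM and 800000 nM, a 1.3-fold higher number from compound 1 to compound 3 (0.11 log units; within the scatter).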

Compound 3, half-maximal inhibitory concentration: 98900 nM
The estimate for compound 3 lay 3.5-fold (0.55 log units) above the measured number, and the stated range ends above it.
By their numbers in this assay, from the lowest: compound 3; then compound 1; then compound 2.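

In this assay, the methyl on this aromatic carbon proves dispensable: taking it away to leave 3-methylphenyl gives a stronger inhibitor (a 2.8-fold lower number from compound 1 to compound 3 (0.44 log units; beyond the scatter)), a change the earlier whole-ring swap could not isolate. The 3-methylphenyl group also stands well ahead of 2-fluorophenyl (a 5.7-fold lower number from compound 2 to compound 3 (0.75 log units; beyond the scatter)), so compound 3 now has the lowest number of the three. Nothing available explains why removing this methyl helps. On these data alone, whether an unsubstituted phenyl would go further, or how a chlorine or methoxy group would fare on this carbon, stays open.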